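The compounds below may be only part of what the source reports. "The series", "measured", "known", "first", "only" and "open" are said of these compounds alone.

Working notes on the series.

Within the data shown here, compound 1 `Cn1c(-c2ccc(O)cc2)nc2c(NC3CCCC3)ncnc21` sits second highest of the three numbers so far in an assay on CHO cells for displacement of a labelled ligand from adenosine receptor A1 (Homo sapiens), read by scintillation counting, with a stated time of 3 h (on this read-out lower numbers stand for stronger inhibition and higher numbers for weaker inhibition), where compound 1 gives 17 nM. Compound 3 `Cn1c(-c2ccccc2)nc2c(NC3CCC3)ncnc21` gives the lower number in this assay, with 3.2 nM, but it differs from compound 1 in two places, so only the two values themselves can be set side by side. Among the measured compounds shown here, compound 2 `Cn1c(-c2ccc(C(=O)O)cc2)nc2c(NC3CCCC3)ncnc21` gives 54000 nM in this assay, and the single step of a 3200-fold higher number from compound 1 to compound 2 (3.50 log units; beyond the scatter) is the only one-place change measured from compound 1.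

Compound 4 `Cc1cccc(-c2nc3c(NC4CCCC4)ncnc3n2C)c1` is not yet measured. It differs from compound 1 as follows: 3-methylphenyl in place of 4-hydroxyphenyl on an aromatic carbon. The hydroxy that leaves here is the same group replaced by carboxy in the step from compound 1 to compound 2, but nothing on a 3-methylphenyl has been measured, so that step does not tell the direction of this one. Compound 3, with an unsubstituted phenyl at the same place, suggests that the hydroxy is not required for a low number. The expected step is therefore small, a 1.2-fold higher number from compound 1 to compound 4 (0.07 log units; within the scatter), with no clear direction beyond the scatter. For compound 4 the estimate in this assay is 20 nM, with a range from 5 nM to 80 nM.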

Compound 4, inhibition constant: 6.2 nM
Compound 4: middle estimate off by 3.2-fold (0.51 log units), on the high side; low and high end bracket the measured number.
By their numbers in this assay, from the lowest: compounds 3 and 4 (each within the scatter of the next); then compound 1; then compound 2.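

At the aromatic carbon between the two ring nitrogen atoms, replacing 4-hydroxyphenyl with 3-methylphenyl on the core of compound 1 gives a 2.7-fold lower number from compound 1 to compound 4 (0.44 log units; beyond the scatter) in this assay. Among these compounds, this is the first one-place change at this position that lowers the number, so with the rest of the structure held constant, the hydroxy is not required for a low number and a ring with no hydrogen-bond donor or acceptor is tolerated here. Nothing available accounts for this step, and since the hydroxy leaves and the methyl enters in the same change, their contributions cannot be separated.

The compounds shown leave open how 4-methylphenyl or 3-hydroxyphenyl would read on this same core, which would separate the identity of the group from where it sits on the ring. They also leave open whether an amine on the phenyl ring would be tolerated as well as the methyl or would instead raise the number, as the carboxylic acid does.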